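Swapping benzyl for 3-methoxyphenyl on the anilinic nitrogen

The compounds below may be only part of what the source reports. "The series", "measured", "known", "first", "only" and "open" are said of these compounds alone.

Compound 1 `CCOC(=O)CN(Cc1ccccc1)c1nc(NCc2ccccc2)ncc1[N+](=O)[O-]`: in a functional assay on MDA-MB-231 cells (Homo sapiens) for antiproliferative activity, read by MTT assay, with a stated time of 48 h (on this read-out higher numbers stand for weaker inhibition and lower numbers for stronger inhibition), compound 1 gives 82400 nM.
Compound 2 `CCOC(=O)CNc1nc(NCc2ccccc2)ncc1[N+](=O)[O-]`: in this assay compound 2 gives 22300 nM.

Among the compounds with values here, compound 2 stands lowest of the two numbers; its only neighbour is compound 1, and the step of a 3.7-fold lower number from compound 1 to compound 2 (0.57 log units; beyond the scatter) is what sets them apart. Compound 3 `CCOC(=O)CNc1nc(Nc2cccc(OC)c2)ncc1[N+](=O)[O-]` differs from compound 2 by 3-methoxyphenyl in place of benzyl on a nitrogen on an aromatic ring. Within the data shown here, no measured step touches this change: the one measured step concerns a different nitrogen, so it gives no guide to direction. Compound 3 is therefore expected near compound 2, with a wide range and a 1.1-fold lower number from compound 2 to compound 3 (0.05 log units; within the scatter), an estimate of 20000 nM (from 5000 nM to 80000 nM).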

Compound 3, half-maximal inhibitory concentration: 31300 nM
The estimate for compound 3 lay 1.6-fold (0.19 log units) below the measured number; measured number inside the range.
By their numbers in this assay, from the lowest: compounds 2 and 3 (each within the scatter of the next); then compound 1.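

In this assay, the exchange gives a 1.4-fold higher number from compound 2 to compound 3 (0.15 log units; within the scatter), so this nitrogen, which the earlier step did not touch, tolerates 3-methoxyphenyl in place of benzyl without a change beyond the scatter. The oxygen and hydrogen-bond acceptor that enter with 3-methoxyphenyl therefore leave the number within the scatter in this pair. No supporting evidence is available to explain this result. On these data alone, whether a carboxylic acid or an amine on the aromatic ring would shift the number remains open. So does the effect of a longer chain in place of benzyl.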